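A Brominated Hydroxyphenyl Hydrazone on a Shared Triazole Core

The source may hold more compounds than are shown below. What is called first, only, known or untested is meant among the compounds shown, and "the series" means these compounds.

In a functional assay on HCT-116 cells (Homo sapiens) for inhibition, read by MTT assay, with a stated time of 48 h (on this read-out higher numbers stand for weaker inhibition and lower numbers for stronger inhibition), compound 1 `Fc1ccccc1CSc1nnc(-c2ccncc2)n1-c1ccccc1` gives 12000 nM. Compound 2 `O=C(CSc1nnc(-c2ccncc2)n1-c1ccccc1)N/N=C/c1ccc(O)cc1` carries the same core but a hydrazone arm ending in a hydroxyphenyl group. In this assay compound 2 gives > 50000 nM, which is a limit of the assay and not a measured number. Compound 2 therefore stands at the limit of > 50000 nM in this assay, at which 1 of the 2 values shown sits, and no number of its own is known for it.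

Compound 3 `O=C(CSc1nnc(-c2ccncc2)n1-c1ccccc1)N/N=C/c1cc(Br)ccc1O` differs from compound 2 in one place: 5-bromo-2-hydroxyphenyl in place of 4-hydroxyphenyl on a carbon with a double bond to nitrogen. For the measured compounds named here, no measured pair in this set shows a change of this kind, so there is no step to lean on, and the expectation rests on compound 2 alone. Compound 3 is expected to remain weak in this assay, and the step from compound 2 to compound 3 is estimated at an at least 1.1-fold lower number from compound 2 to compound 3 (0.04 log units; that floor lies within the scatter), a change no larger than the scatter. Compound 3 is expected to give about 45000 nM, within a range from 15000 nM to 150000 nM, with a real chance that the assay again reports only a limit.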

Compound 3, half-maximal inhibitory concentration: 1990 nM
Estimate against measurement, compound 3: 23-fold (1.35 log units) above; the measured number lies below the stated range.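

In this assay, replacing 4-hydroxyphenyl with 5-bromo-2-hydroxyphenyl on the carbon with a double bond to nitrogen gives an at least 25-fold lower number from compound 2 to compound 3 (1.40 log units; beyond the scatter). This step is only a floor, because compound 2 has a limit and not a measured number: the limit of > 50000 nM in this assay, at which 1 of the 3 values shown sits. Even so, the result shows that the aryl group at the end of the hydrazone arm is a place where one change can move the read-out well beyond the scatter, which compound 2 alone could not show.

The change does two things at once: a bromine enters the ring, and the hydroxyl's number in the group's name shifts from 4 to 2, so the compounds shown cannot say which of the two matters, or whether the two must act together. A plain 2-hydroxyphenyl group would help to separate the two, and a 5-chloro-2-hydroxyphenyl group would test whether bromine itself is needed or another halogen can take its place.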